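Cyclohexyloxy in place of arylsulfanyl on a benzoylguanidine core

A few compounds are considered here, and "the series" means these few. Any claim that something is new, unique, unknown or untested is made for them only; others in the source may bear on it.

Measured compounds and values:
Compound 1 `Cc1cc(-c2cc(Cl)cc(Cl)c2)c(S(C)(=O)=O)cc1C(=O)N=C(N)N`: 130 nM
Compound 2 `CCSc1cc(C)c(C(=O)N=C(N)N)cc1S(C)(=O)=O`: 5.9 nM
Compound 3 `Cc1cc(Sc2ccc(Cl)cc2)c(S(C)(=O)=O)cc1C(=O)N=C(N)N`: 19 nM

In a functional assay for inhibition of sodium/hydrogen exchanger (Oryctolagus cuniculus) (on this read-out lower numbers stand for stronger inhibition and higher numbers for weaker inhibition), compound 3 stands second among the three numbers; its nearest neighbour is compound 2 at a 3.2-fold higher number from compound 2 to compound 3 (0.51 log units; beyond the scatter), its furthest compound 1 at a 6.8-fold lower number from compound 1 to compound 3 (0.84 log units; beyond the scatter). Compound 4 `Cc1cc(OC2CCCCC2)c(S(C)(=O)=O)cc1C(=O)N=C(N)N` has not been measured. Its change from compound 3 is cyclohexyloxy in place of (4-chlorophenyl)sulfanyl on an aromatic carbon.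

Going by the values given here, two measured steps bear on this. The step of a 3.2-fold higher number from compound 2 to compound 3 (0.51 log units; beyond the scatter) shows that an ethyl on the sulfur gave a lower number than a 4-chlorophenyl. The step of a 22-fold lower number from compound 1 to compound 2 (1.34 log units; beyond the scatter) shows that a 3,5-dichlorophenyl bound directly to the ring gave the highest number of the set. Compound 4 carries a non-aromatic ring through an oxygen, a group closer in kind to the ethylsulfanyl of compound 2 than to the aromatic substituents of compounds 1 and 3. Among the compounds with values here, no measured step covers a change from sulfur to oxygen at this position, so the size is uncertain, but a lower number is the expected direction.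

The expected step is therefore a 2.4-fold lower number from compound 3 to compound 4 (0.38 log units; beyond the scatter). For compound 4 the estimate is 8 nM, within 3 nM to 25 nM.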

Compound 4, half-maximal inhibitory concentration: 37 nM
Estimate against measurement, compound 4: 4.6-fold (0.67 log units) below; measured number above the stated range.
By their numbers in this assay, from the lowest: compound 2; then compounds 3 and 4 (each within the scatter of the next); then compound 1.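

In this assay, the exchange of (4-chlorophenyl)sulfanyl for cyclohexyloxy (a 1.9-fold higher number from compound 3 to compound 4 (0.29 log units; within the scatter)) stays within the scatter, so at this position, ortho to a methylsulfonyl group, these two groups are not told apart, even though they differ in the linking atom and in the kind of ring they carry. A non-aromatic group at this place does not by itself bring the low number of compound 2: replacing its ethylsulfanyl with cyclohexyloxy gives a 6.3-fold higher number from compound 2 to compound 4 (0.80 log units; beyond the scatter), while the step from the directly bound 3,5-dichlorophenyl (a 3.5-fold lower number from compound 1 to compound 4 (0.55 log units; beyond the scatter)) shows that cyclohexyloxy still gives a lower number than that group. No measurement among the data shown accounts for any of these steps.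

The step between compound 2 and compound 4 changes the linking atom and the carbon group together, so the share of each remains unresolved. An ethoxy group or a cyclohexylsulfanyl group on the shared core would separate the two changes, and a cyclohexylamino group would show how a nitrogen link compares with the oxygen and sulfur links.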